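Swapping 3-chlorophenyl for 4-methoxyphenyl on the shared core

The compounds below may be only part of what the source reports. "The series", "measured", "known", "first", "only" and "open" are said of these compounds alone.

Measured in a functional assay on M21 cells (Homo sapiens) for antiproliferative activity, read by sulforhodamine B assay, with a stated time of 48 h (on this read-out lower numbers stand for stronger inhibition and higher numbers for weaker inhibition), so far:
Compound 1 `COc1cccc(OS(=O)(=O)c2ccc(N3CCN(C)C3=O)cc2)c1` gives 1600 nM
Compound 2 `CN1CCN(c2ccc(S(=O)(=O)Oc3cccc(F)c3)cc2)C1=O` gives 5800 nM
Compound 3 `CN1CCN(c2ccc(S(=O)(=O)Oc3cccc(Cl)c3)cc2)C1=O` gives 1600 nM

Compound 3 stands level with compound 1, and together they hold the lowest of the three numbers. The remaining gap is the step of a 3.6-fold lower number from compound 2 to compound 3 (0.56 log units; beyond the scatter) and it counts as real.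

Compound 4 `COc1ccc(OS(=O)(=O)c2ccc(N3CCN(C)C3=O)cc2)cc1` awaits measurement in this assay and carries 4-methoxyphenyl in place of 3-chlorophenyl on an oxygen with the rest unchanged. Two other measured steps bear on this swap. Exchanging methoxy for chloro gave no change at the digits printed from compound 1 to compound 3 (within the scatter) so these two groups have read alike so far. Exchanging methoxy for fluoro gave a 3.6-fold higher number from compound 1 to compound 2 (0.56 log units; beyond the scatter) and only fluoro stood apart. Among the measured compounds shown here, no measured step moves a group to another place on the ring, so that part of the change is untested and widens the uncertainty.

The expected result is a 1.3-fold higher number from compound 3 to compound 4 (0.10 log units; within the scatter) with no clear shift foreseen. Compound 4 is estimated at 2000 nM with an expected range from 700 nM to 6000 nM in this estimate.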

Compound 4, half-maximal inhibitory concentration: > 100000 nM
Compound 4: a limit, no number; the forecaster's own chance of this, stated with the estimate: 8%; middle value at least 50-fold (1.69 log units) from the limit.
By their numbers in this assay, from the lowest: compounds 1 and 3 (each within the scatter of the next); then compound 2. At a limit, above all of these: compound 4.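

In this assay compound 4 reads only as a limit, not a number: the limit of > 100000 nM in this assay, at which 1 of the 4 values shown sits.

The most telling step is an at least 62-fold higher number from compound 1 to compound 4 (1.79 log units; beyond the scatter) with the same methoxy group on both compounds, as 3-methoxyphenyl in compound 1 and 4-methoxyphenyl in compound 4. The steps of an at least 62-fold higher number from compound 3 to compound 4 (1.79 log units; beyond the scatter) and an at least 17-fold higher number from compound 2 to compound 4 (1.23 log units; beyond the scatter) are also large, and all three exceed anything seen among compounds 1, 2 and 3, so in this small set, where the group sits on this ring matters more than whether it is methoxy, fluoro or chloro.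

The compounds shown leave open whether 4-chlorophenyl or 4-fluorophenyl would behave like 4-methoxyphenyl, so this drop cannot yet be tied to methoxy alone. As far as these compounds go, how an amine or a carboxylic acid on this ring would read also remains open.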